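The source may report more compounds than this note shows. Statements on the series, on what has been measured and on what is new or still open speak of the compounds shown alone.

Compound 1 `Cc1ccc(-n2nc(C(=O)Nc3ccc(Oc4ncnc5[nH]ccc45)cc3)c(C)cc2=O)cc1` and compound 2 `Cc1ccc(-n2nc(C(=O)Nc3ccc(Oc4ncnc5[nH]ccc45)c(F)c3)c(C)cc2=O)cc1` share one core and differ in a single place, a fluorine on an aromatic carbon. In a functional assay on PC-3 cells (Homo sapiens) for cytotoxicity, read by MTT assay, with a stated time of 72 h (on this read-out higher numbers stand for weaker inhibition and lower numbers for stronger inhibition), compound 1 gives 9610 nM, while compound 2 gives 20400 nM. The step is a 2.1-fold higher number from compound 1 to compound 2 (0.33 log units; beyond the scatter). Within the data shown here, compound 2 therefore stands at the higher of the two numbers measured, with compound 1 as its only neighbour. Compound 3 `Cc1cc(=O)n(-c2cccc(C(F)(F)F)c2)nc1C(=O)Nc1ccc(Oc2ncnc3[nH]ccc23)c(F)c1` is still unmeasured; it keeps the fluorine of compound 2 and changes the group on the aromatic nitrogen: 3-(trifluoromethyl)phenyl in place of 4-methylphenyl on an aromatic nitrogen. Among the measured compounds shown here, no measured step concerns this position. For the measured compounds named here, the one step known, a 2.1-fold higher number from compound 1 to compound 2 (0.33 log units; beyond the scatter), is a different change, so it gives no guide to the size or direction of this one. With nothing to point either way, compound 3 is expected to sit near compound 2, estimated at 20000 nM in this assay, with a range from 8000 nM to 50000 nM. This expectation amounts to a 1.0-fold lower number from compound 2 to compound 3 (0.01 log units; within the scatter).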

Compound 3, half-maximal inhibitory concentration: 15600 nM
Compound 3: middle estimate off by 1.3-fold (0.11 log units), on the high side, within the range that was stated.
By their numbers in this assay, from the lowest: compounds 1, 3 and 2 (each within the scatter of the next, the first and the last beyond it).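

In this assay, 3-(trifluoromethyl)phenyl in place of 4-methylphenyl on the aromatic nitrogen gives a 1.3-fold lower number from compound 2 to compound 3 (0.12 log units; within the scatter). Among these compounds, this is the first reading at this position, and it shows that, with the aromatic fluorine of compound 2 kept, this exchange of aryl groups leaves the number within the scatter, though all of these numbers lie in a weak range. Nothing measured here explains this result.

Among the compounds shown here, the single step changes both the substituent and its place on the phenyl ring, so the two contributions cannot be told apart, and whether the same exchange would behave alike without the aromatic fluorine stays open. Also open, as far as these compounds go, is how this position would respond to a plain phenyl group, an amine or a carboxylic acid.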